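Swapping the Ring Substituent of Compound 2 for a Chain

This account rests on a few compounds, and the source may have more. Where it says the series, first, only, none or still open, it means among the compounds named here.

Among the measured compounds shown here, in an ADME assay on microsomes from liver (Homo sapiens) for metabolic stability, with a stated time of 30 min, tested at 1 uM (a higher number here means that more of the compound is left, a lower number that less of the compound is left), compound 2 `CC[C@@H]1C(=O)N(C)c2cnc(-n3ccnc3-c3ccccc3)nc2N1[C@H]1CCOC1` gives 17%, the lowest of the three known numbers: compound 1 `CC[C@@H]1C(=O)N(C)c2cnc(-n3ccnc3-c3ccc(F)cc3)nc2N1[C@H]1CCOC1` gives 58% and compound 3 `CC[C@@H]1C(=O)N(C)c2cnc(-n3ccnc3-c3ccc(F)cc3)nc2N1C1COC1` gives 74%. Compound 4 `CC[C@@H]1C(=O)N(C)c2cnc(-n3ccnc3-c3ccccc3)nc2N1CCC(F)(F)F` differs from compound 2 by 3,3,3-trifluoropropyl in place of oxolan-3-yl on a nitrogen on an aromatic ring in a ring. Two measured steps exist. a number 41 percentage points lower from compound 1 to compound 2 (beyond the scatter) concerns the fluoro group, not the part changed here. a number 16 percentage points higher from compound 1 to compound 3 (beyond the scatter) changes the same nitrogen on an aromatic ring in a ring, but swaps one ring for another rather than for a chain. For the measured compounds named here, no measured step covers a chain entering there, so only a small shift in this assay is expected, in either direction. Compound 4 is therefore estimated at 25%, between 8% and 50%. This corresponds to an expected a number 8 percentage points higher from compound 2 to compound 4 (within the scatter).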

Compound 4, percent of the compound remaining in the Homo sapiens assay: 0%
Estimate against measurement, compound 4: 25 percentage points above, and the stated range ends above it.
By their numbers in the Homo sapiens assay, from the lowest: compound 4; then compound 2; then compound 1; then compound 3.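

Among the compounds shown here, putting a chain on this nitrogen is not a neutral change: in the Homo sapiens assay it gives a number 17 percentage points lower from compound 2 to compound 4 (beyond the scatter), whereas the earlier compounds showed only one ring replacing another here. In a physicochemical assay for lipophilicity (a higher number here means a more lipophilic compound, a lower number a more polar compound), compound 2 gives 1.9 and compound 4 gives 3.1. The lower stability may therefore go with higher lipophilicity, though one pair cannot prove this: the measured partition coefficient of compound 2, 1.9, and of compound 4, 3.1, a number 1.20 log units higher (beyond the scatter)

Compound 4 removes the ring and brings in fluorine in a single change, and the compounds shown do not separate these two effects. On these data alone, how a plain propyl chain on this nitrogen would behave remains open.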